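The source may hold more compounds than are shown below. What is called first, only, known or untested is meant among the compounds shown, and "the series" means these compounds.

- compound 1 `O[C@@H]1[C@@H](O)[C@H](Cc2ccccc2)O[C@H](COCc2ccccc2)[C@H]1O`: "not active" (no number reported)
- compound 2 `CCCC[C@H]1O[C@H](COCc2ccccc2)[C@@H](OCc2ccccc2)[C@H](OCc2ccccc2)[C@H]1O`: "not active" (no number reported)
- compound 3 `O[C@@H]1[C@@H](OCc2ccccc2)[C@H](O)[C@@H](COCc2ccccc2)O[C@H]1Cc1ccccc1`: 35300 nM

Going by the values given here, in a functional assay on HL-60 cells (Homo sapiens) for antiproliferative activity, read by MTT assay (a lower number here means a stronger inhibitor, a higher number a weaker inhibitor), only one of these three compounds has a number. Compound 1 and compound 2 gave none, and compound 3 reads 35300 nM, so there is no series of values in which to rank it.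

The next compound to be tested is compound 4 `OC[C@H]1O[C@@H](Cc2ccccc2)[C@H](O)[C@@H](OCc2ccccc2)[C@@H]1O`. It differs from compound 3 by one change: hydrogen in place of benzyl on an oxygen on a saturated carbon. In words, hydrogen stands in place of benzyl on an oxygen on a saturated carbon, so benzyloxy becomes hydroxy.

Among the compounds with values here, no step between measured compounds is available to show how large such a change might be, so the evidence is thin. Two of the three compounds gave no number, which makes a modest loss of activity the likelier outcome, and a result of no measurable activity would be no surprise. The expected change is a 1.7-fold higher number from compound 3 to compound 4 (0.23 log units; within the scatter), towards a weaker inhibitor. For compound 4 the estimated value is 60000 nM, with an expected range from 25000 nM to 150000 nM.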

Compound 4, half-maximal inhibitory concentration: "not active" (no number reported)
Nothing numeric was reported for compound 4; there is nothing to compare the estimate with.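

In this assay, going by these compounds alone, compound 4 has no number to compare with that of compound 3, so no step between the two can be read. No measured evidence bears on this result. The compounds shown leave open how far changing benzyloxy to hydroxy shifts activity.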